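Replacing a methoxyethyl chain with a hydroxy-methylethyl group

The source may hold more compounds than are shown below. What is called first, only, known or untested is meant among the compounds shown, and "the series" means these compounds.

Measured so far in a functional assay on KG-1 cells (Homo sapiens) for antiproliferative activity; a higher number here means that more compound is needed for the effect, a lower number that less compound is needed:
- compound 1, `NC(=O)c1cc(Cl)c2c(Cl)c(C#CCCO)n([C@H]3CCCNC3)c2n1`: 56 nM
- compound 2, `NC(=O)c1cc(Cl)c2c(Cl)c(C#CC3COCCO3)n([C@H]3CCCNC3)c2n1`: 77 nM; 203 nM (2 entries)
- compound 3, `COCCC#Cc1c(Cl)c2c(Cl)cc(C(N)=O)nc2n1[C@H]1CCCNC1`: 39 nM

Compound 3 gives the lowest of the two single numbers in this assay. Its nearest neighbour is compound 1, and the step of a 1.4-fold lower number from compound 1 to compound 3 (0.16 log units; within the scatter) lies within the scatter, so the two cannot be told apart. Compound 2 has several entries, (the several entries of compound 2 in this assay, 77 nM; 203 nM (2 entries)), which themselves show how far repeat measurements can spread.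

Compound 4, `CC(C)(O)C#Cc1c(Cl)c2c(Cl)cc(C(N)=O)nc2n1[C@H]1CCCNC1`, differs from compound 3 by a change on the alkyne side chain: 1-hydroxy-1-methylethyl in place of 2-methoxyethyl on a triple-bonded carbon. Within the data shown here, only one measured step bears on this change, that from compound 1 to compound 3, which swaps a hydrogen for a methyl on the oxygen and stays within the scatter. It does not cover moving the oxygen onto a branched carbon, so it gives only a weak guide. With no measured step beyond the scatter on this chain, no step beyond the scatter is expected in this assay either.

Compound 4 is therefore expected to give 60 nM in this assay, within a range of 25 nM to 150 nM, an estimated step of a 1.5-fold higher number from compound 3 to compound 4 (0.19 log units; within the scatter) from compound 3.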

Compound 4, half-maximal effective concentration: 302 nM
For compound 4 the middle estimate is 5.0-fold (0.70 log units) below the measured one; the whole stated range lies below it.
By their numbers in this assay, from the lowest: compounds 3 and 1 (each within the scatter of the next); then compound 4.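

In this assay, among these compounds, this side chain on the triple-bonded carbon proves sensitive to how its atoms are arranged: rearranging the same atoms gives a 7.7-fold higher number from compound 3 to compound 4 (0.89 log units; beyond the scatter), the first step here beyond the scatter. The 2-hydroxyethyl chain also carries a hydroxy group, yet 1-hydroxy-1-methylethyl in its place gives a 5.4-fold higher number from compound 1 to compound 4 (0.73 log units; beyond the scatter), so the presence of a hydroxy group alone does not keep the number low, and the build of the chain around the oxygen matters as well. The gap is also no mere repeat-to-repeat spread, as it is wider than the difference between the repeat entries of a single compound: the several entries of compound 2 in this assay, 77 nM; 203 nM (2 entries)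

On these data alone, what stays open is whether the methyl groups or the placing of the oxygen on the carbon bonded to the triple-bonded carbon drives the step, a question that an unbranched hydroxymethyl chain would help to separate. It is also unclear whether a branched chain carrying an amine in place of the hydroxy group would follow the same course.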